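The source may hold more compounds than are shown below. What is called first, only, known or untested is meant among the compounds shown, and "the series" means these compounds.

Compounds measured so far in an assay (strain Wistar) for inhibition of Hormone-sensitive lipase (Rattus norvegicus), read by spectrophotometry; on this read-out lower numbers stand for stronger inhibition and higher numbers for weaker inhibition:

Compound 1, `Cc1c(Cc2cc3ccccc3n2C)c(=O)on1C(=O)N1CCCCC1`, gives 17 nM.
Compound 2, `Cc1c(C(C)C)c(=O)on1C(=O)N1CCNCC1`, gives > 1000 nM; this value is a limit of the assay, not a number.
Compound 3, `Cc1c(C(C)C)c(=O)on1C(=O)N1CCN(c2ccccc2)CC1`, gives 6 nM.

Among the two numbers available, compound 3 has the lowest; the nearest is compound 1, a somewhat higher number, and the gap between them lies beyond the scatter. The remaining value is the limit for compound 2 noted above.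

Compound 4, `Cc1c(C(C)C)c(=O)on1C(=O)N1CCN(c2ccccc2Cl)CC1`, has not yet been measured. It differs from compound 3 in one place: chloro in place of hydrogen on an aromatic carbon.

Among the compounds with values here, only one measured step touches the same part of the molecule: an at least 160-fold lower number from compound 2 to compound 3 (2.22 log units; beyond the scatter). That step, however, added the whole phenyl group to the ring amine nitrogen, whereas the move to compound 4 keeps that phenyl and adds a chloro on it. Within the data shown here, no measured pair shows what a substituent on that phenyl does in this assay, so the size and direction of the coming step cannot be read from the data. Compound 4 is therefore expected to sit close to compound 3, with the estimated step of no change at the digits printed from compound 3 to compound 4 (within the scatter) lying within the scatter. The estimate for compound 4 in this assay is 6 nM, with a range from 2 nM to 20 nM.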

Compound 4, half-maximal inhibitory concentration: 30 nM
Beside the measured number, compound 4's estimate is 5.0-fold (0.70 log units) below it, and the stated range ends below it.
By their numbers in this assay, from the lowest: compound 3; then compounds 1 and 4 (each within the scatter of the next). At a limit, above all of these: compound 2.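

Within the data shown here, compound 4 gives the first measured look at a substituent on the phenyl group, and in this assay chloro in place of hydrogen on this aromatic carbon, ortho to a large group, moves the number up: a 5.0-fold higher number from compound 3 to compound 4 (0.70 log units; beyond the scatter). The 2-chlorophenyl group still leaves a large step in the same direction as phenyl when set against the free ring amine, with an at least 33-fold lower number from compound 2 to compound 4 (1.52 log units; beyond the scatter). Compound 2 stands at a limit of the assay and not at a number, so that step has a bound and no exact size: the limit of > 1000 nM in this assay, at which 1 of the 4 values shown sits.

The compounds shown leave open whether chloro on another carbon of the phenyl group would give the same step, and whether the step belongs to chloro in particular or would also appear with a methyl, methoxy or fluoro group at this place. Also open, as far as these compounds go, is what an amine or a carboxylic acid on that phenyl group would do in this assay.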